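A Small Change on a Very Weakly Active Compound

The compounds below may be only part of what the source reports. "The series", "measured", "known", "first", "only" and "open" are said of these compounds alone.

Compound 1 `c1ccc(Cc2nnc(-c3c[nH]c4ccccc34)o2)cc1`: 934000 nM in a functional assay on MIA PaCa-2 cells (Homo sapiens) for cytotoxicity, read by MTT assay; on this read-out lower numbers stand for stronger inhibition and higher numbers for weaker inhibition
Compound 2 `COc1cc(-c2nnc(-c3cn(C)c4ccccc34)o2)ccc1OCc1ccccc1`: 1400 nM in this assay
Compound 3 `COc1cc(-c2nnc(-c3c[nH]c4ccccc34)o2)ccc1O`: > 1000000 nM in this assay, which is a limit of the assay and not a number

Of the two numbers measured in this assay, compound 1 has the higher one, meaning the weaker inhibition; the nearest is compound 2, whose far lower number lies beyond the usual scatter of such measurements. For compound 3 the assay gives only (the limit of > 1000000 nM in this assay, at which 1 of the 3 values shown sits), so nothing more than a limit is known for it. Compound 2 differs from compound 1 in several places at once, so no single change can be read from that pair.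

Compound 4 `FC(F)(F)c1nnc(-c2c[nH]c3ccccc23)o1` has not yet been measured in this assay. It differs from compound 1 in one place: trifluoromethyl in place of benzyl on an aromatic carbon. Among the compounds with values here, no measured pair in this set shows the same change, so there is no direct guide to its effect. Since compound 1 already sits at a very high number, the step from compound 1 to compound 4 is expected to be a 1.0-fold lower number from compound 1 to compound 4 (0.02 log units; within the scatter), no more than the scatter in either direction. Compound 4 is therefore expected to give about 900000 nM, within a range from 250000 nM to 3000000 nM, and it may also come back only as a limit.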

Compound 4, half-maximal inhibitory concentration: > 1000000 nM
Compound 4: a limit, no number; the forecaster's own chance of this, stated with the estimate: 40%; middle value at least 1.1-fold (0.04 log units) from the limit.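

Within the data shown here, putting trifluoromethyl in place of benzyl on this aromatic carbon gives the first comparison in the set between two compounds that differ in one place, and in this assay it reads as an at least 1.0-fold higher number from compound 1 to compound 4 (0.02 log units; that floor lies within the scatter). Compound 4 gives > 1000000 nM, which is a limit of the assay and not a number, so the step has only a floor and its true size cannot be read. What the pair does show is that this replacement of benzyl, with its six-membered aromatic ring, by a group with no ring brings no sign of stronger inhibition at this position, and compound 4 now stands at the top of the measurable range: the limit of > 1000000 nM in this assay, at which 2 of the 4 values shown sit.

The compounds shown leave open whether any other group at this position, such as an amine, a carboxylic acid or a longer chain, would bring the number down from this very high level. Compound 2 gives 1400 nM, but it differs from compound 1 in several places at once, so it cannot tell which change matters or what part, if any, this position plays.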